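Fluoro in place of chloro: compound 2 to compound 3

The source may report more compounds than this note shows. Statements on the series, on what has been measured and on what is new or still open speak of the compounds shown alone.

Measured in an ADME assay on L6 cells (Rattus norvegicus) for cytotoxicity; a higher number here means a weaker inhibitor, a lower number a stronger inhibitor:
Compound 1 `CN(C)NC(=O)c1cc([N+](=O)[O-])ccc1Cl`: > 410000 nM (a limit of the assay)
Compound 2 `O=C(NN(c1ccccc1)c1ccccc1)c1cc([N+](=O)[O-])ccc1Cl`: 13300 nM

Among the measured compounds shown here, compound 2 holds the only actual number so far, 13300 nM. Compound 3 `O=C(NN(c1ccccc1)c1ccccc1)c1cc([N+](=O)[O-])ccc1F` differs from it by fluoro in place of chloro on an aromatic carbon, para to a nitro group. For the measured compounds named here, no measured step covers this exchange, so only a small move in this assay is expected, towards the weaker side and close to the usual scatter. The expected step is a 1.2-fold higher number from compound 2 to compound 3 (0.08 log units; within the scatter). Compound 3 is estimated at 16000 nM, with an expected range of 6000 nM to 45000 nM.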

Compound 3, half-maximal inhibitory concentration: 3200 nM
Beside the measured number, compound 3's estimate is 5.0-fold (0.70 log units) above it; measured number outside the range, below it.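

This position, ortho to a large group and para to a nitro group, is sensitive to a single-atom exchange in this assay: fluoro in place of chloro gives a 4.2-fold lower number from compound 2 to compound 3 (0.62 log units; beyond the scatter). The change swaps one halogen for another, with no ring, hydrogen-bond donor, acceptor or net charge entering or leaving, yet the step lies beyond the scatter. Nothing measured here accounts for this step.

From the compounds shown here alone, it remains open whether bromo, a nitrile or an amine at this position would continue the move. Going by these compounds, whether the same exchange holds on the core of compound 1 also remains open.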